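Lengthening the chain of compound 2

This account rests on a few compounds, and the source may have more. Where it says the series, first, only, none or still open, it means among the compounds named here.

In a functional assay on MCF7 cells (Homo sapiens) for antiproliferative activity, with a stated time of 5 days (on this read-out lower numbers stand for stronger inhibition and higher numbers for weaker inhibition), compound 1 (`CCCCCc1ccc2[nH]c(-c3ccc(OC)cc3)c(C=C(C#N)C#N)c2c1`) gives 76 nM. Compound 2 (`CCCCc1ccc2[nH]c(-c3ccc(C(F)(F)F)cc3)c(C=C(C#N)C#N)c2c1`) gives 150 nM. These two numbers lie within the usual scatter of each other, so compound 2 does not stand apart from compound 1 on the data so far.

Compound 3 (`CCCCCc1ccc2[nH]c(-c3ccc(C(F)(F)F)cc3)c(C=C(C#N)C#N)c2c1`) has not yet been measured in this assay. It differs from compound 2 in one place: methyl in place of hydrogen on a saturated chain carbon, four bonds along the chain from an aromatic carbon. This puts methyl in place of hydrogen on a saturated chain carbon, four bonds along the chain from an aromatic carbon. Cut one bond further out, the same difference reads propyl to butyl.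

Within the data shown here, no two measured compounds differ in one place only, so the data show no size for such a step. In this assay no change beyond the scatter is expected, with a slight lean towards a lower number. The estimate is anchored on compound 2 at 150 nM. The expected change is a 1.3-fold lower number from compound 2 to compound 3 (0.10 log units; within the scatter), an estimated step within the scatter. The estimated value for compound 3 is 120 nM, with an expected range of 55 nM to 260 nM.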

Compound 3, half-maximal inhibitory concentration: 100 nM
Estimate against measurement, compound 3: 1.2-fold (0.08 log units) above; measured number inside the range.
By their numbers in this assay, from the lowest: compounds 1, 3 and 2 (each within the scatter of the next).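

Methyl in place of hydrogen on a saturated chain carbon, four bonds along the chain from an aromatic carbon, gives a 1.5-fold lower number from compound 2 to compound 3 (0.18 log units; within the scatter) in this assay, so this first measured step at the chain does not separate the two compounds. Compound 3 also links the chain series to the methoxy compound: trifluoromethyl in place of methoxy on an aromatic carbon, with the chain the same, gives a 1.3-fold higher number from compound 1 to compound 3 (0.12 log units; within the scatter), and in this assay these two groups are not told apart at this chain length. No separate measurement on these compounds bears on either result.

Going by these compounds, each of these two steps rests on a single pair of compounds, so it remains open whether a longer chain, or a chain ending in an amine or a carboxylic acid, would stay within the scatter of compound 3. On these data alone, it also remains open whether a group such as a chlorine atom or a hydroxyl group, in place of trifluoromethyl on the same aromatic carbon, would give a step beyond the scatter.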